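A few compounds are considered here, and "the series" means these few. Any claim that something is new, unique, unknown or untested is made for them only; others in the source may bear on it.

Measured compounds:
compound 1 `CC(C(=O)O)c1nn(Cc2cn3cc(OCC4CC4)c(Cl)cc3n2)c2ccccc2c1=O` — 15 nM in a functional assay on HFL1 cells for antagonist activity at sphingosine 1-phosphate receptor 2 (Homo sapiens), read by ELISA, with a stated time of 24 h, in the presence of a further agent that is not named here; a lower number here means a stronger inhibitor, a higher number a weaker inhibitor
compound 2 `O=C(O)Cn1nc(Cc2cn3cc(OCC4CC4)c(Cl)cc3n2)c2ccccc2c1=O` — 275 nM in this assay

For the measured compounds named here, of the two numbers in this assay, compound 1 has the lower one, and its gap to compound 2 lies beyond the usual scatter; no single-point step connects these two. Compound 3 `O=C(O)Cc1nn(Cc2cn3cc(OCC4CC4)c(Cl)cc3n2)c2ccccc2c1=O` is compound 1 with hydrogen in place of methyl on a saturated chain carbon bound to an aromatic carbon and a carbonyl carbon. Going by the values given here, no measured step of this kind exists. The expectation is a loss of some potency, a step of moderate size in a 2.7-fold higher number from compound 1 to compound 3 (0.43 log units; beyond the scatter) toward the weaker side. For compound 3 the estimated value in this assay is 40 nM, with a range from 12 nM to 150 nM.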

Compound 3, half-maximal inhibitory concentration: 60 nM
Compound 3: middle estimate off by 1.5-fold (0.18 log units), on the low side; the range from low to high includes it.
By their numbers in this assay, from the lowest: compound 1; then compound 3; then compound 2.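

In this assay, for the compounds shown here, replacing 1-carboxyethyl with carboxymethyl gives the first measured step at this saturated chain carbon bound to an aromatic carbon and a carbonyl carbon (a 4.0-fold higher number from compound 1 to compound 3 (0.60 log units; beyond the scatter)). The methyl thus contributes to potency in this pair, although the step is modest.

On these data alone, whether an ethyl group or a fluorine atom on this carbon would match methyl remains open, as does the effect of replacing the carboxylic acid with a primary amide. Nothing available explains the size or direction of the step.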